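The source may hold more compounds than are shown below. What is called first, only, known or untested is meant among the compounds shown, and "the series" means these compounds.

For the measured compounds named here, in a functional assay on KB cells (Homo sapiens) for inhibition, read by MTT assay, with a stated time of 24 h, tested at 100 ug/mL (a higher number here means more inhibition of growth at the concentration tested, a lower number less inhibition of growth), compound 1 `O=C(CCCCC1CCSS1)Nc1ccc(OC(F)(F)F)cc1` gives 90.1%, the higher of the two numbers so far. Compound 2 `O=C(CCCCC(S)CCS)Nc1cccc(C(F)(F)F)c1` gives 30.5%, which leaves a gap beyond the scatter. The next compound to consider is compound 3 `O=C(CCCCC(S)CCS)Nc1ccc(OC(F)(F)F)cc1`, which keeps the rest of compound 1 and changes one group: a group of 5 heavy atoms (3 carbon, 2 sulfur; no ring) in place of a group of 5 heavy atoms (3 carbon, 2 sulfur; one five-membered non-aromatic ring with 2 hetero atoms), on a saturated chain carbon, four bonds along the chain from a carbonyl carbon. The ring gives way to the open-chain 1,3-disulfanylpropyl group, on the same saturated chain carbon. Going by the values given here, no measured pair isolates this change. Among the compounds with values here, compound 2, the only measured compound with the 1,3-disulfanylpropyl group, stands at 30.5%, so a fall beyond the scatter is expected, though compound 2 also differs from compound 3 elsewhere. The expected step is a number 35.1 percentage points lower from compound 1 to compound 3 (beyond the scatter), with wide uncertainty. For compound 3 the estimated value in this assay is 55%, with an expected range of 28% to 85%.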

Compound 3, percent growth inhibition at one concentration: 73.3%
Compound 3: middle estimate off by 18.3 percentage points, on the low side, within the range that was stated.
By their numbers in this assay, from the lowest: compound 2; then compound 3; then compound 1.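

In this assay the ring at this position, on a saturated chain carbon, four bonds along the chain from a carbonyl carbon, can now be read directly against its open-chain form: replacing it with the 1,3-disulfanylpropyl group gives a number 16.8 percentage points lower from compound 1 to compound 3 (beyond the scatter). The loss is modest, and compound 3 still gives 73.3%, so in this pair the closed ring is not required for substantial inhibition of growth at the concentration tested. Nothing available bears on the reason for this step.

The compounds shown leave open whether the same ring opening gives a similar step alongside the trifluoromethyl group of compound 2. Also open, on these data alone, is how a longer chain, or an amine in place of the sulfur atoms, would read at this position.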